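The source may hold more compounds than are shown below. What is called first, only, known or untested is meant among the compounds shown, and "the series" means these compounds.

Compound 1 `O=S(=O)(NCCNC(=S)Nc1cc(C(F)(F)F)cc(C(F)(F)F)c1)c1ccc(-c2ccccc2O[C@H]2CC[C@@H](O)CC2)s1` gives 6300 nM in a functional assay on RS4-11 cells (Homo sapiens) for inhibition, read by CCK-8 assay, with a stated time of 48 h; on this read-out higher numbers stand for weaker inhibition and lower numbers for stronger inhibition. Going by the values given here, compound 2 `CC(C)c1ccc(Oc2ccc(O)c(O)c2)c(-c2ccsc2S(=O)(=O)NCCNC(=S)Nc2cc(C(F)(F)F)cc(C(F)(F)F)c2)c1` gives 3700 nM there, and these two values lie within the usual scatter of each other, so the numbers so far do not separate them. Compound 3 `O=S(=O)(NCCNC(=S)Nc1cc(C(F)(F)F)cc(C(F)(F)F)c1)c1ccc(-c2ccccc2Oc2ccc(O)c(O)c2)s1` has yet to be measured in this assay. It keeps the core of compound 1 and carries 3,4-dihydroxyphenyl in place of 4-hydroxycyclohexyl on an oxygen on an aromatic ring. Among the compounds with values here, no measured pair isolates this change, so the expectation leans on compound 2, which also carries 3,4-dihydroxyphenyl and gives 3700 nM. The estimated step of a 1.8-fold lower number from compound 1 to compound 3 (0.26 log units; within the scatter) is expected to be small, towards a lower number, and hardly beyond the scatter. For compound 3 the expected value is estimated at 3500 nM, within a range from 1200 nM to 9000 nM.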

Compound 3, half-maximal inhibitory concentration: 10300 nM
Compound 3: middle estimate off by 2.9-fold (0.47 log units), on the low side; measured number outside the range, above it.
By their numbers in this assay, from the lowest: compounds 2, 1 and 3 (each within the scatter of the next, the first and the last beyond it).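

In this assay, going by these compounds alone, the change from 4-hydroxycyclohexyl to 3,4-dihydroxyphenyl on an oxygen on an aromatic ring gives the first isolated reading at this position: a 1.6-fold higher number from compound 1 to compound 3 (0.21 log units; within the scatter). This step lies within the scatter, so the assay does not separate compound 1 from compound 3, even though a non-aromatic ring with 2 defined stereocentres gives way to an aromatic ring with no stereocentre. No independent measurement bears on this result, and no cause can be assigned to it.

On these data alone, it remains open whether a group of another kind on this oxygen, such as an aminoethyl chain or a carboxylic acid, would move the number beyond the scatter. As far as these compounds go, it is also open whether an unsubstituted phenyl would read differently from 3,4-dihydroxyphenyl at this place.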